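The source may report more compounds than this note shows. Statements on the series, on what has been measured and on what is new or still open speak of the compounds shown alone.

Of the compounds shown here, three of one shared core have been measured in a functional assay on CHO cells for antagonist activity at Glucagon receptor (Homo sapiens), read by cAMP accumulation, with stated times of 30 min and 45 min; on this read-out lower numbers stand for stronger inhibition and higher numbers for weaker inhibition. Compound 1 `C[C@H](c1ccc(C(=O)NCCC(=O)O)cc1)N1C(=O)C(c2cccc(F)c2)=N[C@]12CC[C@@H](C(C)(C)C)CC2` gives 560 nM. Compound 2 `CC(C)(C)[C@H]1CC[C@]2(CC1)N=C(c1cccc(C(F)(F)F)c1)C(=O)N2Cc1ccc(C(=O)NCCC(=O)O)cc1` gives 510 nM, the lowest of the three numbers, though its gap to compound 1 lies within the scatter of repeated measurements, so no order between compound 2 and compound 1 can be read from these two values. Compound 3 `CC(C)[C@H](c1ccc(C(=O)NCc2nn[nH]n2)cc1)N1C(=O)C(c2cc(Cl)cc(Cl)c2)=N[C@]12CC[C@@H](C(C)(C)C)CC2` gives 2200 nM, a number that stands beyond the scatter above compound 2; compound 3 also differs from compound 2 in more than one place, so its value alone does not tell what any single change does.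

Compound 4 `CC(C)(C)[C@H]1CC[C@]2(CC1)N=C(c1ccc(Cl)c(Cl)c1)C(=O)N2Cc1ccc(C(=O)NCCC(=O)O)cc1` differs from compound 2 in one place: 3,4-dichlorophenyl in place of 3-(trifluoromethyl)phenyl on a carbon with a double bond to nitrogen. For the measured compounds named here, no measured pair in this set shows this change by itself. With compound 2 at 510 nM and no direct comparison to lean on, compound 4 is expected to give 650 nM, within a range from 220 nM to 1900 nM. The step of a 1.3-fold higher number from compound 2 to compound 4 (0.11 log units; within the scatter) is an estimate of a small change, not clearly beyond the scatter in either direction.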

Compound 4, half-maximal inhibitory concentration: 1600 nM
The estimate for compound 4 lay 2.5-fold (0.39 log units) below the measured number; the measured number falls inside the stated range.
By their numbers in this assay, from the lowest: compounds 2 and 1 (each within the scatter of the next); then compounds 4 and 3 (each within the scatter of the next).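

In this assay, for the compounds shown here, this is the first comparison in the set that isolates a single change, and it gives a 3.1-fold higher number from compound 2 to compound 4 (0.50 log units; beyond the scatter). The group on the carbon with a double bond to nitrogen therefore affects the read-out, even though 3-(trifluoromethyl)phenyl and 3,4-dichlorophenyl each hold one six-membered aromatic ring of carbon only and have no hydrogen-bond donors or acceptors and no net charge. Nothing available here accounts for this step.

The compounds shown leave open how this position would respond to an unsubstituted phenyl, or to a phenyl bearing a single chlorine or a nitrile. They also leave open whether the same exchange would give a similar step with a tetrazole in place of the carboxylic acid.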